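This account rests on a few compounds, and the source may have more. Where it says the series, first, only, none or still open, it means among the compounds named here.

Measured so far in an ADME assay on HeLa cells (Homo sapiens) for cytotoxicity, read by sulforhodamine B assay, with a stated time of 48 h, tested at 10 uM; a higher number here means more inhibition at the concentration tested (going by the name of the read-out), a lower number less inhibition:

Compound 1, `COc1nc2ccc(Br)cc2cc1C(c1ccccc1)n1cc(C2CC2)nn1`; in this assay compound 1 gives -5.84%.
Compound 2, `COc1nc2ccc(Br)cc2cc1C(c1ccccc1)n1cc(-c2ccc(OC(F)(F)F)cc2)nn1`; compound 2 gives -2.24%.
Compound 3, `COc1nc2ccc(Br)cc2cc1C(c1ccccc1)n1cc(CCCCCO)nn1`; compound 3 gives 1.08%.

Compound 3 sits at the top of these three numbers, yet the gaps to the other two are small: the step of a number 3.3 percentage points higher from compound 2 to compound 3 (within the scatter) and the step of a number 6.9 percentage points higher from compound 1 to compound 3 (within the scatter) are both within the scatter, as is the step of a number 3.6 percentage points higher from compound 1 to compound 2 (within the scatter). All three compounds share one core and differ only in the group on the same aromatic carbon, and none of these exchanges moved the read-out beyond the noise of repeated measurement.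

Compound 4, `CCCCCCc1cn(C(c2ccccc2)c2cc3cc(Br)ccc3nc2OC)nn1`, continues the same series. It differs from compound 3 in one place: methyl in place of hydroxy on a saturated chain carbon, five bonds along the chain from an aromatic carbon. The three measured steps bear on this change in that they show exchanges at that position leaving the read-out essentially flat. On that basis the step of a number 1.1 percentage points lower from compound 3 to compound 4 (within the scatter) is expected to lie within the scatter. Compound 4 is therefore estimated at 0%, with a range from -10% to 10%.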

Compound 4, a percentage reported as inhibition, at one concentration (the size of the read-out at that concentration, not a potency): -0.97%
Compound 4: middle estimate off by 1 percentage points, on the high side; measured number inside the range.
By their numbers in this assay, from the lowest: compounds 1, 2, 4 and 3 (each within the scatter of the next).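

In this assay the change from hydroxy to methyl, on a saturated chain carbon, five bonds along the chain from an aromatic carbon, gives a number 2.1 percentage points lower from compound 3 to compound 4 (within the scatter) and so leaves the read-out level. This is the first change shown within the chain itself, as the earlier steps exchanged the whole group on the aromatic carbon, and it indicates that the hydroxy is not needed to keep the number where it stands. The hexyl group also stands level with the earlier groups, with 4-(trifluoromethoxy)phenyl replaced by hexyl giving a number 1.3 percentage points higher from compound 2 to compound 4 (within the scatter) and cyclopropyl replaced by hexyl giving a number 4.9 percentage points higher from compound 1 to compound 4 (within the scatter).

From the compounds shown here alone, whether an amine or a carboxylic acid at this chain carbon, or a longer chain, would move the read-out beyond the scatter remains open. No supporting evidence is available to explain why this position stays flat.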